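Nitro introduction on the methoxyphenyl ring: acid versus ethyl ester

The source may hold more compounds than are shown below. What is called first, only, known or untested is meant among the compounds shown, and "the series" means these compounds.

Measured so far in a functional assay on KB cells (Homo sapiens) for antiproliferative activity, read by MTT assay, with a stated time of 72 h; a higher number here means a weaker inhibitor, a lower number a stronger inhibitor:
compound 1 `COc1ccc(-c2sc(C(=O)O)cc2-c2cc(OC)c(OC)c(OC)c2)cc1` gives 10400 nM
compound 2 `COc1ccc(-c2sc(C(=O)O)cc2-c2cc(OC)c(OC)c(OC)c2)cc1[N+](=O)[O-]` gives 35900 nM
compound 3 `CCOC(=O)c1cc(-c2ccc(OC)cc2)c(-c2cc(OC)c(OC)c(OC)c2)s1` gives 10200 nM

Compound 1 and compound 2 differ by one change, (nitro in place of hydrogen on an aromatic carbon), and that change gave a 3.5-fold higher number from compound 1 to compound 2 (0.54 log units; beyond the scatter). Compound 3 and compound 1 differ in their cores; that difference is not broken down here, and their two values in this assay lie within the usual scatter of each other.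

Compound 4 `CCOC(=O)c1cc(-c2ccc(OC)c([N+](=O)[O-])c2)c(-c2cc(OC)c(OC)c(OC)c2)s1` has not yet been measured. It stands to compound 3 as compound 2 stands to compound 1: the change is nitro in place of hydrogen on an aromatic carbon, the same change in the same surroundings. From that single precedent the step is expected to be a 3.5-fold higher number from compound 3 to compound 4 (0.55 log units; beyond the scatter), resting on the earlier step from compound 1 to compound 2. Compound 4 is therefore estimated at 36000 nM, with a range of 18000 nM to 72000 nM.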

Compound 4, half-maximal inhibitory concentration: 24000 nM
For compound 4 the middle estimate is 1.5-fold (0.18 log units) above the measured one, and the stated range covers the measured number.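

In this assay the change from 4-methoxyphenyl to 4-methoxy-3-nitrophenyl on the ethyl ester gives a 2.4-fold higher number from compound 3 to compound 4 (0.37 log units; beyond the scatter) and so runs the same way as on the carboxylic acid. The size of the step does not separate the two cores: the same change on two cores in this assay, a 3.5-fold higher number (0.54 log units; beyond the scatter) from compound 1 to compound 2 and a 2.4-fold higher number (0.37 log units; beyond the scatter) from compound 3 to compound 4, 1.5-fold (0.17 log units) apart, within the scatter of two such steps. Within the data shown here, this supports carrying the nitro step between the acid and the ethyl ester in this one assay, but with only two pairs it shows nothing about other cores or other assays.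

From the compounds shown here alone, whether an amine or a fluorine on the same aromatic carbon would give a step of similar size remains open. So does whether the nitro step would hold on a primary amide of the shared core.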